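Swapping a Cyano Aryl for a Methyl Aryl Amide

A few compounds are considered here, and "the series" means these few. Any claim that something is new, unique, unknown or untested is made for them only; others in the source may bear on it.

The measured compounds, all in a toxicity assay on THP-1 cells (Homo sapiens) for inhibition; on this read-out lower numbers stand for higher toxicity in this test and higher numbers for lower toxicity in this test:
Compound 1, `CCCCn1c(-c2ccc(OC)cc2)cnc1NC(=O)c1ccc(F)cc1`: compound 1 gives > 100000 nM, a limit of the assay rather than a number.
Compound 2, `COc1ccc(-c2cnc(NC(=O)c3cccc([N+](=O)[O-])c3)n2C)cc1`: compound 2 gives > 100000 nM, again a limit.
Compound 3, `COc1ccc(-c2cnc(NC(=O)c3cccc(C#N)c3)n2C)cc1`: compound 3 gives > 100000 nM, also a limit.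

So compound 3 stands at the same limit as the other two; no measured number places it higher or lower than either. Among the compounds with values here, the only step available from one measured compound to another, cyano in place of nitro on an aromatic carbon, is a step that the two limits leave unreadable from compound 2 to compound 3, so it gives no readable size.

Compound 4, `COc1ccc(-c2cnc(NC(=O)c3ccc(C)cc3)n2C)cc1`, differs from compound 3 by 4-methylphenyl in place of 3-cyanophenyl on a carbonyl carbon. Nothing in the measured steps tells how this change would move the read-out in this assay. Because all three values sit at the limit of > 100000 nM in this assay, at which 3 of the 3 values shown sit, the step of a number no higher from compound 3 to compound 4 (the limit leaves the size open) is expected to stay within the scatter, with compound 4 most likely reported again as a limit. For compound 4 the estimated value is 100000 nM, within a range from 50000 nM to 200000 nM.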

Compound 4, half-maximal cytotoxic concentration: > 100000 nM
Compound 4: a limit, no number; the forecaster's own chance of this, stated with the estimate: 85%; the middle value lies on the limit itself.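

Compound 3 and compound 4 both sit at a limit of the assay, so no step can be read between them in this assay. The compounds shown leave open how any of these changes moves the read-out, with every reading stopped at the same point: the limit of > 100000 nM in this assay, at which 4 of the 4 values shown sit.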